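The compounds below may be only part of what the source reports. "The series", "measured", "known", "first", "only" and "open" are said of these compounds alone.

Within the data shown here, compound 1, `CCN(CC)S(=O)(=O)c1ccc(S(=O)(=O)N2CCC[C@@H](C(=O)NC3COC3)C2)cc1`, stands as the higher of the two numbers known so far in a functional assay on BXPC-3 cells (Homo sapiens) for inhibition, read by MTT assay, with a stated time of 7 days; a higher number here means a weaker inhibitor, a lower number a stronger inhibitor: compound 1 gives 13800 nM. Among the measured compounds shown here, the only comparator is compound 2, `O=C([C@@H]1CCCN(S(=O)(=O)c2ccc(S(=O)(=O)N3CC[C@H](O)C3)cc2)C1)N1CCC(F)(F)CC1`, which in this assay gives 580 nM, a number well below that of compound 1 and beyond the usual scatter; the two compounds differ in more than one place, so no single step between them can be read.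

Compound 3, `CCN(CC)S(=O)(=O)c1ccc(S(=O)(=O)N2CCC[C@@H](C(=O)N3CCC(OC)CC3)C2)cc1`, is the next compound to be measured. It differs from compound 1 by the change (4-methoxypiperidin-1-yl in place of (oxetan-3-yl)amino on a carbonyl carbon). 

Because compound 2, which carries a six-membered amide ring of the same kind, gives 580 nM, the author expects compound 3 to move in the lower direction, by a step of a 3.9-fold lower number from compound 1 to compound 3 (0.60 log units; beyond the scatter) that is likely larger than the scatter but well short of the full gap to compound 2, since compound 2 also differs at the sulfonamide. The estimate for compound 3 in this assay is 3500 nM, within a range from 900 nM to 12000 nM.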

Compound 3, half-maximal inhibitory concentration: 1420 nM
Compound 3: the middle estimate sits 2.5-fold (0.39 log units) above what was measured, and the stated range covers the measured number.
By their numbers in this assay, from the lowest: compound 2; then compound 3; then compound 1.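

In this assay, among these compounds, replacing (oxetan-3-yl)amino with 4-methoxypiperidin-1-yl on a carbonyl carbon gives a 9.7-fold lower number from compound 1 to compound 3 (0.99 log units; beyond the scatter), the first single-place step in this set, and it shows that a change at this position alone, with the rest of the core of compound 1 held fixed, can move the number beyond the scatter. The exchange alters several things at once: the four-membered ring gives way to a six-membered one, the group grows from 5 to 8 heavy atoms, and the hydrogen-bond donor of the leaving group is lost, so this one step cannot say which of these differences matters. No measurement shown here accounts for the size of the step.

Compound 2 differs from both other compounds in more than one place, so its steps cannot be read, and the contribution of the other sulfonamide end remains unresolved. Also open, going by these compounds, is whether the methoxy group or the ring itself matters, which a plain piperidin-1-yl or a morpholin-4-yl on the same carbonyl carbon could address, and whether a cyclohexylamino group, which keeps the amide hydrogen, would separate ring size from the loss of that hydrogen.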